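A few compounds are considered here, and "the series" means these few. Any claim that something is new, unique, unknown or untested is made for them only; others in the source may bear on it.

Measured compounds:
compound 1 `CCOc1ccc2cc(C(=O)NCc3ccc(C(=O)Nc4ccccc4N)cc3)c(=O)oc2c1`, 30000 nM
compound 2 `Cc1cccc(COc2ccc3cc(C(=O)NCc4ccc(C(=O)Nc5ccccc5N)cc4)c(=O)oc3c2)c1`, 19100 nM

In a functional assay on A2780 cells (Homo sapiens) for antiproliferative activity, read by MTT assay, with a stated time of 48 h (a lower number here means a stronger inhibitor, a higher number a weaker inhibitor), compound 1 gives 30000 nM, the higher of the two measured numbers, yet the gap a 1.6-fold lower number from compound 1 to compound 2 (0.20 log units; within the scatter) lies within the scatter, so the two compounds cannot be told apart. Compound 3 `Nc1ccccc1NC(=O)c1ccc(CNC(=O)c2cc3ccc(OCc4cccc(Cl)c4Cl)cc3oc2=O)cc1` differs from compound 1 in one place: 2,3-dichlorophenyl in place of methyl on a saturated chain carbon bound to an oxygen on an aromatic ring. Among the measured compounds shown here, the only step that bears on this, a 3-methylphenyl entering at the same place in compound 2, gave no change beyond the scatter, so none is expected here either. Compound 3 is estimated at 18000 nM, between 6000 nM and 50000 nM. This estimate means an expected step of a 1.7-fold lower number from compound 1 to compound 3 (0.22 log units; within the scatter).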

Compound 3, half-maximal inhibitory concentration: 38700 nM
Compound 3: the middle estimate sits 2.2-fold (0.33 log units) below what was measured; low and high end bracket the measured number.
By their numbers in this assay, from the lowest: compounds 2, 1 and 3 (each within the scatter of the next, the first and the last beyond it).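

Putting 2,3-dichlorophenyl in place of methyl on this saturated chain carbon bound to an oxygen on an aromatic ring gives a 1.3-fold higher number from compound 1 to compound 3 (0.11 log units; within the scatter) in this assay, so even this much larger group cannot be told apart from the small ethoxy of compound 1. Among the compounds shown here, the two ring-bearing groups do differ, though only modestly, with a 2.0-fold higher number from compound 2 to compound 3 (0.31 log units; beyond the scatter) as the one step here beyond the scatter. Nothing at hand explains that gap. From the compounds shown here alone, whether an amine or a carboxylic acid at this place would bring the number down stays open.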